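The compounds below may be only part of what the source reports. "The series", "measured", "known", "first", "only" and "open" are said of these compounds alone.

The series shares one core, seen in compound 1 `O=C(CCCCC#Cc1ccccn1)c1ncc(-c2ccccn2)o1`, whose end group is a pyridyl-capped alkyne; in an assay for inhibition of Fatty-acid amide hydrolase 1 (Rattus norvegicus) (on this read-out higher numbers stand for weaker inhibition and lower numbers for stronger inhibition), compound 1 gives 280 nM. Compound 2 `COc1ccc(CCCCCCC(=O)c2ncc(-c3ccccn3)o2)cc1` carries a 4-methoxyphenyl tail and gives 6.2 nM. Compound 3 `CSc1cccc(CCCCCCC(=O)c2ncc(-c3ccccn3)o2)c1` carries a 3-(methylsulfanyl)phenyl tail and gives 4.2 nM, the lowest of the three numbers, with compound 2 nearest and compound 1 furthest. Among the measured compounds shown here, the only single-place step measured is a 1.5-fold lower number from compound 2 to compound 3 (0.17 log units; within the scatter), a swap of the substituent on the aryl tail.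

Compound 4 `O=C(CCCCCSc1ccccc1)c1ncc(-c2ccccn2)o1` differs from compound 3 by phenylsulfanyl in place of 3-(methylsulfanyl)benzyl on a saturated chain carbon, five bonds along the chain from a carbonyl carbon: the aryl group is now joined through sulfur and the saturated chain is shorter. For the measured compounds named here, no measured step covers a change of this kind; the step from compound 2 to compound 3 shows only that the aryl tail tolerates different substituents, and compound 1 shows that a very different end group costs much potency. Compound 4 is therefore expected to remain a strong inhibitor in this assay, with a modest weakening a 3.6-fold higher number from compound 3 to compound 4 (0.55 log units; beyond the scatter) plausible, and is estimated at 15 nM, between 4 nM and 60 nM.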

Compound 4, inhibition constant: 3 nM
The estimate for compound 4 lay 5.0-fold (0.70 log units) above the measured number; the measured number lies below the stated range.
By their numbers in this assay, from the lowest: compounds 4, 3 and 2 (each within the scatter of the next, the first and the last beyond it); then compound 1.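

The aryl group at this place, on a saturated chain carbon five bonds along the chain from a carbonyl carbon, can be joined through sulfur without a clear loss in this assay: phenylsulfanyl in place of 3-(methylsulfanyl)benzyl gives a 1.4-fold lower number from compound 3 to compound 4 (0.15 log units; within the scatter). Against the 4-methoxybenzyl group the same phenylsulfanyl gives a 2.1-fold lower number from compound 2 to compound 4 (0.32 log units; beyond the scatter), a modest step, while against the pyridyl-capped alkyne end group the change is a 93-fold lower number from compound 1 to compound 4 (1.97 log units; beyond the scatter), so a plain phenyl ring with no substituent is enough to reach the low numbers of this series. Nothing available explains why these numbers fall as they do.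

The compounds shown leave open whether a longer chain carrying phenylsulfanyl would read the same. They also leave open how an amine or a carboxylic acid on the phenyl ring would fare at this place.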